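The compounds below may be only part of what the source reports. "The series", "measured", "known", "first", "only" and "open" are said of these compounds alone.

Measured so far, all in a functional assay on aorta (strain Wistar) for inhibition, with Thoracic aorta (Rattus norvegicus) as the target; on this read-out higher numbers stand for weaker inhibition and lower numbers for stronger inhibition:

compound 1 `CCOc1nc(-c2cc3ccccc3o2)cc(-c2ccc3ccccc3c2)c1C#N` — 423000 nM
compound 2 `CCOc1nc(-c2cc3ccccc3o2)cc(-c2ccc(Br)cc2)c1C#N` — 227000 nM
compound 3 `CCOc1nc(-c2cc3ccccc3o2)cc(-c2ccc(C)cc2)c1C#N` — 290000 nM

Of these three numbers compound 3 has the second highest. Its nearest neighbour is compound 2, and the change between them, methyl in place of bromo on an aromatic carbon, gave a 1.3-fold higher number from compound 2 to compound 3 (0.11 log units; within the scatter). Compound 1, with the larger naphthalen-2-yl group in the same place, is the furthest away, yet even there the step to compound 3 was only a 1.5-fold lower number from compound 1 to compound 3 (0.16 log units; within the scatter). Going by the values given here, nothing so far has moved this assay beyond its scatter.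

Compound 4 `CCOc1nc(-c2cc3ccccc3o2)cc(-c2ccc(OC)cc2)c1C#N` is the next compound, differing from compound 3 in one place: methoxy in place of methyl on an aromatic carbon. Among the compounds with values here, the steps that bear on this are the exchanges at the same aromatic carbon already seen, from compound 1 to compound 3 and from compound 2 to compound 3, both within the scatter. Another small group in that place is therefore expected to give a step of similar size, a 1.0-fold lower number from compound 3 to compound 4 (0.02 log units; within the scatter), with no direction that could be told from the noise.

On that basis compound 4 is estimated at 280000 nM in this assay, with a range from 120000 nM to 650000 nM.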

Compound 4, half-maximal inhibitory concentration: 204000 nM
Compound 4: middle estimate off by 1.4-fold (0.14 log units), on the high side; the range from low to high includes it.
By their numbers in this assay, from the lowest: compounds 4, 2, 3 and 1 (each within the scatter of the next, the first and the last beyond it).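

In this assay, 4-methoxyphenyl in place of 4-methylphenyl brings an oxygen and a hydrogen-bond acceptor to this position, yet the exchange gives a 1.4-fold lower number from compound 3 to compound 4 (0.15 log units; within the scatter) and so cannot be told apart from repeat-measurement noise. Methoxy in place of bromo at the same carbon gives a 1.1-fold lower number from compound 2 to compound 4 (0.05 log units; within the scatter) and is equally unreadable, so methyl, bromo and methoxy cannot be ranked here. Going by these compounds alone, what is new is a 2.1-fold lower number from compound 1 to compound 4 (0.32 log units; beyond the scatter) and is the first step in this set to pass the scatter, if only modestly, while 4-bromophenyl and 4-methylphenyl in the same place stayed within it when compared with naphthalen-2-yl, so the gap between naphthalen-2-yl and the single-ring groups is only just emerging.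

No supporting measurement is available to explain any of these steps. Going by these compounds, it remains open whether an amine, a carboxylic acid or a longer chain such as butoxy at this same carbon would move the number clearly beyond the scatter, and whether changing the groups elsewhere on the shared core would matter more than any exchange made here.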